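Thiourea aryl swap on the shared core

The source may hold more compounds than are shown below. What is called first, only, known or untested is meant among the compounds shown, and "the series" means these compounds.

Compound 1 `NC(=O)c1c(NC(=O)c2ccccc2Cl)sc2c1CCNC2` gives 28700 nM in a functional assay on MKN-74 cells (Homo sapiens) for antiproliferative activity, with a stated time of 24 h; a lower number here means a stronger inhibitor, a higher number a weaker inhibitor. Among the measured compounds shown here, compound 2 `NC(=O)c1c(NC(=O)c2ccccc2Cl)sc2c1CCN(Cc1c(Cl)cccc1Cl)C2` gives 4740 nM, and the step of a 6.1-fold lower number from compound 1 to compound 2 (0.78 log units; beyond the scatter) is the only single-point step measured so far. Compound 3 `NC(=O)c1c(NC(=O)c2ccccc2Cl)sc2c1CCN(C(=S)Nc1cccc3ccccc13)C2` gives 20700 nM, the second highest of the three numbers: against compound 1 the gap is within the scatter, against compound 2 it lies beyond it. Compound 4 `NC(=O)c1c(NC(=O)c2ccccc2Cl)sc2c1CCN(C(=S)Nc1ccccc1I)C2` differs from compound 3 by 2-iodophenyl in place of naphthalen-1-yl on an amide-type nitrogen. For the measured compounds named here, no measured step touches the aryl group on the thiocarbonyl nitrogen; the one measured step sits on the ring amine nitrogen and does not bear on this change. Compound 4 is therefore estimated at 20000 nM, with a range from 6000 nM to 60000 nM. The expected step is a 1.0-fold lower number from compound 3 to compound 4 (0.01 log units; within the scatter), that is, nothing beyond the scatter.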

Compound 4, half-maximal inhibitory concentration: 2630 nM
The estimate for compound 4 lay 7.6-fold (0.88 log units) above the measured number; measured number outside the range, below it.
By their numbers in this assay, from the lowest: compounds 4 and 2 (each within the scatter of the next); then compounds 3 and 1 (each within the scatter of the next).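

Replacing naphthalen-1-yl with 2-iodophenyl gives a 7.9-fold lower number from compound 3 to compound 4 (0.90 log units; beyond the scatter) in this assay and so shows that the aryl group on the thiocarbonyl nitrogen can move the number beyond the scatter. On the amine nitrogen in the ring, the 2-iodophenyl thiourea gives an 11-fold lower number from compound 1 to compound 4 (1.04 log units; beyond the scatter) against hydrogen, while a 1.8-fold lower number from compound 2 to compound 4 (0.26 log units; within the scatter) stays within the scatter of the 2,6-dichlorobenzyl group. No evidence on hand bears on this change. Open, as far as these compounds go, is whether the iodine or the loss of the second aromatic ring carries the step, which phenyl, 2-chlorophenyl or 2-methoxyphenyl on that nitrogen could separate.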